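A few compounds are considered here, and "the series" means these few. Any claim that something is new, unique, unknown or untested is made for them only; others in the source may bear on it.

Compound 1, `COc1ccc(-c2cc(/N=C3/NC(=O)CS3)cs2)cc1`, sits at a limit in this assay: > 50000 nM.
Compound 2, `O=C1CS/C(=N\c2csc(-c3ccc(Cl)cc3)c2)N1`, also sits at a limit: > 50000 nM.
Compound 3, `COc1ccc(/C=C2\S/C(=N\c3csc(-c4ccc(Cl)cc4)c3)NC2=O)cc1`: 28100 nM.

For the measured compounds named here, in a functional assay on SW-620 cells (Homo sapiens) for cytotoxicity, read by MTT assay, with a stated time of 72 h (a higher number here means a weaker inhibitor, a lower number a stronger inhibitor), compound 3 gives 28100 nM, the only actual number among the three. The other two values are limits, as the limit of > 50000 nM in this assay, at which 2 of the 3 values shown sit, records. Compound 4 is `O=C1N/C(=N/c2csc(-c3ccc(Cl)cc3)c2)S/C1=C\c1ccc(Br)cc1`, and it differs from compound 3 in one place: bromo in place of methoxy on an aromatic carbon. Going by the values given here, the single measured step, a step that the two limits leave unreadable from compound 1 to compound 2, runs between two limits and so cannot be sized, and it exchanges methoxy for chloro rather than bromo. Among the compounds with values here, no measured step therefore bears directly on this change. For compound 4 the expected step is a 1.0-fold lower number from compound 3 to compound 4 (0.00 log units; within the scatter), none beyond the scatter. Compound 4 is estimated at 28000 nM, between 10000 nM and 70000 nM.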

Compound 4, half-maximal inhibitory concentration: 700 nM
Estimate against measurement, compound 4: 40-fold (1.60 log units) above; the whole stated range lies above it.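

In this assay, putting 4-bromophenyl in place of 4-methoxyphenyl gives a 40-fold lower number from compound 3 to compound 4 (1.60 log units; beyond the scatter). This shows that the group on this six-membered aromatic ring, para to a large group, can strongly change the read-out, something the earlier step, made elsewhere on the molecule and unreadable between two limits, could not show. Nothing shown accounts for the size of this step.

On these data alone, only methoxy and bromo have been compared at this place, so it remains open how other groups, such as an amine, a carboxylic acid or a longer chain, would read here.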